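Swapping an aromatic ring for a short chain on a triazene

The source may report more compounds than this note shows. Statements on the series, on what has been measured and on what is new or still open speak of the compounds shown alone.

Of the compounds shown here, two have been measured in a functional assay on L1210 cells (Mus musculus) for antiproliferative activity; a lower number here means a less potent compound, a higher number a more potent compound, by a factor of ten per unit of this negative logarithm. Compound 1, with the structure `CN(C)/N=N/c1ccc(S(N)(=O)=O)cc1C(N)=O`, gives 3.32 in this assay. Compound 2, with the structure `CN(/N=N/c1nc[nH]c1C(N)=O)c1cccs1`, gives 3.87 in this assay. Of the two numbers, that of compound 2 is the higher, and the gap to compound 1 lies beyond the usual scatter of repeated measurements, so compound 2 counts as the more potent of the pair.

Compound 3, with the structure `CCCN(C)/N=N/c1nc[nH]c1C(N)=O`, has not yet been measured. It differs from compound 2 in a single place: propyl in place of thiophen-2-yl on an amine nitrogen. The rest of the molecule, including the shared core with its amide, is unchanged.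

Within the data shown here, no pair of measured compounds here differs in exactly this way, so there is no measured step to lean on. Compound 2 shows that the shared core can reach 3.87 in this assay, and the change to compound 3 keeps that core intact. On that basis a small drop or no shift beyond the scatter is expected from compound 2 to compound 3, namely a number 0.27 log units lower from compound 2 to compound 3 (within the scatter). Compound 3 is therefore estimated to give 3.6 in this assay, within a range from 3 to 4.2.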

Compound 3, logarithm of the reciprocal of the active concentration, log(1/C): 3.58
Estimate against measurement, compound 3: 0.02 log units above; low and high end bracket the measured number.
By their numbers in this assay, from the lowest: compounds 1, 3 and 2 (each within the scatter of the next, the first and the last beyond it).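

On the amine nitrogen of the shared core, the step in this assay is a number 0.29 log units lower from compound 2 to compound 3 (within the scatter) and so the two groups cannot be told apart here. Among these compounds, this is the first direct reading at this position, and it shows that a five-membered aromatic ring holding sulfur is not needed there to keep the number at the level of compound 2, since propyl, a chain with no ring and fewer heavy atoms, gives a result that repeated measurements could not separate from it. Nothing on hand explains why thiophen-2-yl and propyl read alike.

From the compounds shown here alone, how much else this position accepts stays open: a longer chain such as hexyl, a chain ending in an amine or a carboxylic acid, or a phenyl ring could each read quite differently from these two groups. A single step also cannot say whether the same swap would read alike on a different core, such as the core of compound 1.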